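Swapping the Aryl Group on the Acrylamide Chain

The source may hold more compounds than are shown below. What is called first, only, known or untested is meant among the compounds shown, and "the series" means these compounds.

Compound 1 `COc1ccc(C(=O)c2cc(OC)c(OC)c(OC)c2)cc1N` gives 60 nM in a functional assay on HeLa cells (Homo sapiens) for cytotoxicity, read by MTT assay, with a stated time of 72 h; on this read-out higher numbers stand for weaker inhibition and lower numbers for stronger inhibition.
Compound 2 `COc1ccc(C(=O)c2cc(OC)c(OC)c(OC)c2)cc1NC(=O)/C=C/c1ccc(C(F)(F)F)cc1` gives 90 nM in this assay.
Compound 3 `COc1ccc(C(=O)c2cc(OC)c(OC)c(OC)c2)cc1NC(=O)/C=C/c1cccc(OC(F)(F)F)c1` gives 7900 nM in this assay.

Compound 3 stands at the highest number of the three, with compound 2 nearest and compound 1 furthest. For the measured compounds named here, only one measured step touches the position now in question: an 88-fold higher number from compound 2 to compound 3 (1.94 log units; beyond the scatter). That single step already shows that the group on the chain carbon can move the number a long way. Compound 4 `COc1ccc(C(=O)c2cc(OC)c(OC)c(OC)c2)cc1NC(=O)/C=C/c1ccc(N)cc1` carries the change (4-aminophenyl in place of 3-(trifluoromethoxy)phenyl on a double-bonded chain carbon bound to a double-bonded chain carbon). Going by the values given here, the entering 4-aminophenyl group shares its substitution pattern name with the 4-(trifluoromethyl)phenyl of compound 2, and the expectation therefore leans on compound 2 and its 90 nM rather than on compound 3, but the amino group is unlike trifluoromethyl and no measured step covers it, so the range is wide. Compound 4 is expected to show a large step downward in this assay, a 20-fold lower number from compound 3 to compound 4 (1.30 log units; beyond the scatter). Compound 4 is estimated at 400 nM, with a range from 80 nM to 3000 nM.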

Compound 4, half-maximal inhibitory concentration: 14700 nM
For compound 4 the middle estimate is 37-fold (1.57 log units) below the measured one, outside the stated range (above it).
By their numbers in this assay, from the lowest: compounds 1 and 2 (each within the scatter of the next); then compounds 3 and 4 (each within the scatter of the next).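

In this assay, the 4-aminophenyl group does not behave like the 4-(trifluoromethyl)phenyl group, with a 160-fold higher number from compound 2 to compound 4 (2.21 log units; beyond the scatter) for amino in place of trifluoromethyl on an aromatic carbon. The outcome at this place therefore depends on the group itself, and not only on the name of its substitution pattern. The two quite different groups of compound 3 and compound 4 cannot be told apart, since a 1.9-fold higher number from compound 3 to compound 4 (0.27 log units; within the scatter) lies within the scatter. Adding the chain to the amine of the core also carries a large cost here, with a 250-fold higher number from compound 1 to compound 4 (2.39 log units; beyond the scatter), whereas compound 2 at 90 nM stays within the scatter of compound 1.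

Nothing at hand gives a reason for these steps. From the compounds shown here alone, whether a 4-(trifluoromethoxy)phenyl or a 3-(trifluoromethyl)phenyl group on the chain carbon would sit with compound 2 or with compound 3 remains open.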